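Trifluoromethyl in place of fluoro on the pendant phenyl

A few compounds are considered here, and "the series" means these few. Any claim that something is new, unique, unknown or untested is made for them only; others in the source may bear on it.

Of the compounds shown here, three have been measured in a functional assay on Caco-2 cells (Homo sapiens) for antiproliferative activity, read by MTT assay, with a stated time of 24 h; on this read-out lower numbers stand for stronger inhibition and higher numbers for weaker inhibition. The parent compound 1 `c1ccc(C2=NN(c3ccc(-c4ccccc4)nn3)C(c3ccccc3)C2)cc1` gives 40900 nM. Compound 2 `Clc1ccc(C2CC(c3ccccc3)=NN2c2ccc(-c3ccccc3)nn2)cc1` gives 100000 nM, and compound 3 `Fc1ccc(C2CC(c3ccccc3)=NN2c2ccc(-c3ccccc3)nn2)cc1` gives 10000 nM, the lowest number of the three. The steps are a 2.4-fold higher number from compound 1 to compound 2 (0.39 log units; beyond the scatter), a 4.1-fold lower number from compound 1 to compound 3 (0.61 log units; beyond the scatter) and a 10-fold lower number from compound 2 to compound 3 (1.00 log units; beyond the scatter).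

Compound 4 `FC(F)(F)c1ccc(C2CC(c3ccccc3)=NN2c2ccc(-c3ccccc3)nn2)cc1` differs from compound 3 by trifluoromethyl in place of fluoro on an aromatic carbon, on an aromatic carbon of a six-membered aromatic ring of carbon only. The step that bears on it most directly is the exchange of halogens between compound 2 and compound 3: read in the other direction, a 10-fold lower number from compound 2 to compound 3 (1.00 log units; beyond the scatter) shows that going from the single fluorine to the larger chloro raised the number strongly. Trifluoromethyl is larger again than chloro, so a rise in this assay is expected, of a size comparable to that step rather than smaller. Compound 4 is therefore estimated at 40000 nM, between 10000 nM and 100000 nM, which would mean an expected 4.0-fold higher number from compound 3 to compound 4 (0.60 log units; beyond the scatter).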

Compound 4, half-maximal inhibitory concentration: 50000 nM
For compound 4 the middle estimate is 1.3-fold (0.10 log units) below the measured one; low and high end bracket the measured number.
By their numbers in this assay, from the lowest: compound 3; then compounds 1, 4 and 2 (each within the scatter of the next, the first and the last beyond it).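

In this assay, among the compounds shown here, the trifluoromethyl group on this carbon gives a 5.0-fold higher number from compound 3 to compound 4 (0.70 log units; beyond the scatter) as its step away from fluoro, so chloro is no longer the only group that lacks the low number of compound 3. Trifluoromethyl cannot be separated from chloro, with a 2.0-fold lower number from compound 2 to compound 4 (0.30 log units; within the scatter) printed within the scatter, nor from hydrogen, with a 1.2-fold higher number from compound 1 to compound 4 (0.09 log units; within the scatter) also within it, and among the groups shown only fluoro stands clearly apart at this place. No measurement on hand accounts for this difference between fluoro and trifluoromethyl.

The compounds shown leave open whether the low number of compound 3 is particular to fluoro or would also appear with a nitrile, a methoxy group or an amine on this carbon. They also leave open whether the same order would hold on the other phenyl group of the shared core.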